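Shifting a Chlorine on the Ring-Nitrogen Aryl Group

The source may hold more compounds than are shown below. What is called first, only, known or untested is meant among the compounds shown, and "the series" means these compounds.

Compound 1 `Oc1ccc(C2=NN(c3ccc(Cl)cc3)C(c3cccc(Cl)c3)C2)cc1` carries a 4-hydroxyphenyl group and two chlorophenyl groups on a shared core. In an assay on HEK293 cells for inhibition of protein kinase C zeta type (Homo sapiens), read by 33P incorporation, with a stated time of 40 min, in the presence of a further agent that is not named here (on this read-out higher numbers stand for weaker inhibition and lower numbers for stronger inhibition), compound 1 gives < 100 nM, which is a limit of the assay rather than a number. One of the two values shown sits at this limit (the limit of < 100 nM in this assay, at which 1 of the 2 values shown sits), so exactly where compound 1 stands is not known. Among the compounds with values here, compound 2 `Oc1cccc(C2=NN(c3ccc(Cl)cc3)C(c3ccc(Cl)cc3)C2)c1` differs from compound 1 in two places at once, and in this assay compound 2 gives 6500 nM; no single step joins the two, and their two values show only that compound 2 sits far to the weaker side. Compound 3 `Oc1ccc(C2=NN(c3cccc(Cl)c3)C(c3cccc(Cl)c3)C2)cc1` has not yet been measured. 3-chlorophenyl in place of 4-chlorophenyl on an amine nitrogen in a ring — the same atoms, joined differently. Within the data shown here, no step of this kind has been measured here, so the expectation rests on the change itself: a step in this assay of small size, within the scatter or slightly toward weaker inhibition. Compound 3 is therefore estimated at 150 nM in this assay, with a likely range from 30 nM to 800 nM. This estimate corresponds to an expected step of an at least 1.5-fold higher number from compound 1 to compound 3 (0.17 log units; that floor lies within the scatter).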

Compound 3, half-maximal inhibitory concentration: 400 nM
For compound 3 the middle estimate is 2.7-fold (0.43 log units) below the measured one; low and high end bracket the measured number.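

The group on the amine nitrogen in a ring is sensitive to where its chlorine sits: with 3-chlorophenyl in place of 4-chlorophenyl, this assay shows an at least 4.0-fold higher number from compound 1 to compound 3 (0.60 log units; beyond the scatter). Compound 1 and compound 2 differ in two places at once, so they could not show this, whereas compound 1 and compound 3 contain the same atoms, joined differently, and differ in this one group alone. Compound 1 gives < 100 nM, which is a limit of the assay and not a number, so the step gives only a minimum and the true gap may be wider: the limit of < 100 nM in this assay, at which 1 of the 3 values shown sits.

The compounds shown do not tell whether the chlorine is needed on this phenyl ring at all, or how an unsubstituted phenyl group, a fluorophenyl group or a methoxyphenyl group would compare at the same nitrogen. Within the data shown here, they also leave open how much of the weak value of compound 2, 6500 nM, belongs to each of its two differences from compound 1, since no single step separates those changes.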